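The compounds below may be only part of what the source reports. "The series", "measured", "known", "first", "only" and "open" are said of these compounds alone.

Within the data shown here, compound 3 `O=C(NCc1cn(Cc2ccc(F)cc2)nn1)c1cn(-c2ccccc2)nc1-c1ccc(Cl)cc1` sits in the middle of the three compounds measured so far in a functional assay on MIA PaCa-2 cells (Homo sapiens) for antiproliferative activity, read by sulforhodamine B assay, with a stated time of 48 h; on this read-out lower numbers stand for stronger inhibition of growth and higher numbers for weaker inhibition of growth: compound 3 gives 1990 nM, compound 1 `O=C(NCc1cn(Cc2ccc(Cl)cc2)nn1)c1cn(-c2ccccc2)nc1-c1ccccc1` gives 8700 nM, and compound 2 `O=C(NCc1cn(Cc2ccc(Cl)cc2)nn1)c1cn(-c2ccccc2)nc1-c1ccc(F)cc1` gives 280 nM. Compound 4 `O=C(NCc1cn(Cc2ccc(Cl)cc2)nn1)c1cn(-c2ccccc2)nc1-c1ccc(Cl)cc1` is the next compound in this series and has not yet been measured. It differs from compound 3 in one place: chloro in place of fluoro on an aromatic carbon.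

Among the measured compounds shown here, only one single-point step has been measured so far, a 31-fold lower number from compound 1 to compound 2 (1.49 log units; beyond the scatter), and it concerns a different ring from the one changed here, so it cannot be read as a guide to the size of the present change. For the measured compounds named here, compound 2 and compound 3 differ from each other in two places at once, so their values show only that two halogen swaps together move the number, not which swap does what. What is expected for compound 4 therefore rests on general experience with exchanging one halogen for another, which usually gives a small step. For compound 4 a step of a 2.0-fold lower number from compound 3 to compound 4 (0.30 log units; within the scatter) in this assay is estimated, to an expected value of 1000 nM with a range from 300 nM to 4000 nM.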

Compound 4, concentration for 50% growth inhibition: 410 nM
Compound 4: middle estimate off by 2.4-fold (0.39 log units), on the high side; the range from low to high includes it.
By their numbers in this assay, from the lowest: compounds 2 and 4 (each within the scatter of the next); then compound 3; then compound 1.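

In this assay, the choice of halogen matters on the benzyl group: going from 4-fluorobenzyl to 4-chlorobenzyl gives a step beyond the scatter (a 4.9-fold lower number from compound 3 to compound 4 (0.69 log units; beyond the scatter)). The same exchange on the other ring, 4-fluorophenyl to 4-chlorophenyl, stays within the scatter (a 1.5-fold higher number from compound 2 to compound 4 (0.17 log units; within the scatter)), so the two rings do not respond alike to this swap. With the 4-chlorobenzyl group kept, chloro in place of hydrogen on the phenyl ring gives a large step (a 21-fold lower number from compound 1 to compound 4 (1.33 log units; beyond the scatter)), like the one seen with fluoro, so on that ring having a halogen counts for more than which halogen it is.

On these data alone, whether a bromo, methyl or methoxy group, or an amine, at the same place on either ring would behave like chloro remains open. Nothing available explains why the two rings differ.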